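Changing the aryl group on the ring nitrogen of compound 3

This account rests on a few compounds, and the source may have more. Where it says the series, first, only, none or still open, it means among the compounds named here.

Measured in a functional assay on CHO-K1 cells for antagonist activity at transient receptor potential cation channel subfamily V member 1 (Homo sapiens), read by FLIPR; on this read-out lower numbers stand for stronger inhibition and higher numbers for weaker inhibition:
Compound 1, `CC(C(=O)NCc1ccc(C(F)(F)F)nc1Nc1ccccc1)c1ccc(NS(C)(=O)=O)c(F)c1`: 1400 nM
Compound 2, `CC(C(=O)NCc1ccc(C(F)(F)F)nc1N1CCCCCCC1)c1ccc(NS(C)(=O)=O)c(F)c1`: 27.8 nM
Compound 3, `Cc1cccc(N2CCN(c3nc(C(F)(F)F)ccc3CNC(=O)C(C)c3ccc(NS(C)(=O)=O)c(F)c3)CC2)c1`: 39.2 nM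

Compound 3 holds the second highest number of the three; its number and that of compound 2 lie within the scatter of each other, while compound 1 sits far higher. Among the measured compounds shown here, the only step measured so far, a 50-fold lower number from compound 1 to compound 2 (1.70 log units; beyond the scatter), concerns the group attached to the core and is large, but it does not touch the position changed here. Compound 4, `CC(C(=O)NCc1ccc(C(F)(F)F)nc1N1CCN(c2ccc(C(F)(F)F)cc2)CC1)c1ccc(NS(C)(=O)=O)c(F)c1`, differs from compound 3 only by 4-(trifluoromethyl)phenyl in place of 3-methylphenyl on an amine nitrogen in a ring. For the measured compounds named here, no measured step bears on this exchange. With nothing to point either way, a step of a 1.0-fold higher number from compound 3 to compound 4 (0.01 log units; within the scatter) is expected, that is, none beyond the scatter. Compound 4 is therefore estimated at 40 nM in this assay, within a range from 13 nM to 120 nM.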

Compound 4, half-maximal inhibitory concentration: 117 nM
For compound 4 the middle estimate is 2.9-fold (0.47 log units) below the measured one, and the stated range covers the measured number.
By their numbers in this assay, from the lowest: compounds 2 and 3 (each within the scatter of the next); then compound 4; then compound 1.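

In this assay, this position responds to the aryl group on the ring nitrogen: 4-(trifluoromethyl)phenyl in place of 3-methylphenyl gives a 3.0-fold higher number from compound 3 to compound 4 (0.47 log units; beyond the scatter), a modest step. The exchange alters both the substituent and where it sits on the phenyl ring, so this single step cannot separate those two changes. No available evidence accounts for the step. The compounds shown leave open how 4-methylphenyl or 3-(trifluoromethyl)phenyl would compare, as either would change only one of those two features. They also leave open how a pyridine ring would fare here.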